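A few compounds are considered here, and "the series" means these few. Any claim that something is new, unique, unknown or untested is made for them only; others in the source may bear on it.

Measured so far:
compound 1 `CC(C)(C)c1ccc(-c2csc(Nc3cccc4ccccc34)n2)cc1` gives 900 nM
compound 2 `CC(C)(C)c1csc(Nc2ccccc2)n1` gives 4500 nM

Both were tested in an assay on CCRF-CEM cells for displacement of a labelled ligand from C-C chemokine receptor type 4 (Homo sapiens); on this read-out lower numbers stand for stronger inhibition and higher numbers for weaker inhibition. Compound 2 has the higher of the two numbers, and compound 1 sits a clear gap lower, beyond the usual scatter. Compound 3 `CC(C)c1ccccc1Nc1nc(C(C)(C)C)cs1` has not yet been measured; it differs from compound 2 by isopropyl in place of hydrogen on an aromatic carbon. Among the compounds with values here, no step of this kind has been measured, so the expectation is tentative: a modest move towards a lower number seems plausible, but nothing beyond the scatter is assured. The estimate for compound 3 in this assay is 2500 nM, between 700 nM and 9000 nM, an expected step of a 1.8-fold lower number from compound 2 to compound 3 (0.26 log units; within the scatter).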

Compound 3, half-maximal inhibitory concentration: 440 nM
For compound 3 the middle estimate is 5.7-fold (0.75 log units) above the measured one, outside the stated range (below it).
By their numbers in this assay, from the lowest: compound 3; then compound 1; then compound 2.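

Isopropyl on an aromatic carbon of the six-membered ring, ortho to a large group, gives a large change in this assay (a 10-fold lower number from compound 2 to compound 3 (1.01 log units; beyond the scatter)). This position therefore accepts added carbon, and this one small change, with no hydrogen-bond donor or acceptor, moves the number well beyond the usual scatter. No measurement shown here explains the size of this step.

On these data alone, whether methyl, an amine or a carboxylic acid at the same carbon would give a similar step remains open. So does whether isopropyl would have the same effect on the core of compound 1.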